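Adding a Methyl to Compound 1: an Estimate

The source may hold more compounds than are shown below. What is called first, only, known or untested is meant among the compounds shown, and "the series" means these compounds.

Measured so far:
compound 1 `C[C@H]1CC(Cl)=C([Si](C)(C)C)[C@@H](C2CCCCC2)O1`: 61000 nM
compound 2 `C[C@H]1CC(Cl)=C[C@@H](C2CCCCC2)O1`: 79000 nM

Both numbers come from a functional assay on A2780 cells (Homo sapiens) for antiproliferative activity; a lower number here means that less compound is tolerated, a higher number that more compound is tolerated. Compound 1 has the lowest of the two numbers, and its nearest neighbour is compound 2; the step of a 1.3-fold higher number from compound 1 to compound 2 (0.11 log units; within the scatter) shows that taking away the silyl group on the double-bonded ring carbon changes nothing that can be told apart from repeat measurements.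

Compound 3 `CC[C@H]1CC(Cl)=C([Si](C)(C)C)[C@@H](C2CCCCC2)O1` has not been measured. It differs from compound 1 by methyl in place of hydrogen on a saturated chain carbon bound to a saturated ring carbon, so the chain on the saturated ring carbon grows from methyl to ethyl. Among the measured compounds shown here, no measured step touches this chain; the only step available, from compound 1 to compound 2, concerns a different part of the molecule and was itself within the scatter. Nothing in these two values points to a direction for a small change at the chain, so the expectation for compound 3 in this assay is a number close to that of compound 1, with a step of a 1.1-fold lower number from compound 1 to compound 3 (0.02 log units; within the scatter) that stays within the scatter.

Compound 3 is estimated to give 58000 nM, expected to lie between 25000 nM and 130000 nM.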

Compound 3, concentration lethal to 50% of the cells: 75000 nM
Estimate against measurement, compound 3: 1.3-fold (0.11 log units) below, and the stated range covers the measured number.
By their numbers in this assay, from the lowest: compounds 1, 3 and 2 (each within the scatter of the next).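

Among the compounds shown here, this is the first measured look at the chain on the saturated ring carbon: with the silyl group and the rest of the core of compound 1 kept in place, lengthening the chain from methyl to ethyl gives, in this assay, the step (a 1.2-fold higher number from compound 1 to compound 3 (0.09 log units; within the scatter)). The added methyl therefore produces no difference that can be told apart from repeat measurements, so this one small change at this position has no detectable effect on the read-out. No separate measurement bears on this result, and the data offer no explanation for it.

One added carbon is a very small probe, and this single step cannot show whether the position would remain just as indifferent to a longer chain such as propyl or butyl, or to a chain ending in an amine or a carboxylic acid. As far as these compounds go, it also remains open whether the same change from methyl to ethyl would give a similar result on the core of compound 2, where a hydrogen stands in place of the silyl group.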